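The compounds below may be only part of what the source reports. "The series", "measured", "known", "first", "only" and "open" are said of these compounds alone.

Of the compounds shown here, two have been measured in a functional assay on HepG2 cells (Homo sapiens) for antiproliferative activity, read by MTT assay, with a stated time of 48 h; on this read-out lower numbers stand for stronger inhibition and higher numbers for weaker inhibition. Compound 1 `CCOC(=O)CN(Cc1ccccc1)c1nc(Nc2ccccc2)ncc1[N+](=O)[O-]` gives 44400 nM in this assay, and compound 2 `CCOC(=O)CN(Cc1ccccc1)c1nc(Nc2ccc(Cl)cc2)ncc1[N+](=O)[O-]` gives 30900 nM. Going by the values given here, the only step between measured compounds, a 1.4-fold lower number from compound 1 to compound 2 (0.16 log units; within the scatter), comes from putting chloro in place of hydrogen on an aromatic carbon, and it stays within the scatter. Compound 2 therefore has the lower of the two numbers, but its gap to compound 1 is too small to count as a difference.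

Compound 3 `CCOC(=O)CN(Cc1ccccc1)c1nc(Nc2cccc(OC)c2)ncc1[N+](=O)[O-]` has not yet been measured in this assay. Relative to compound 2 the change is 3-methoxyphenyl in place of 4-chlorophenyl on a nitrogen on an aromatic ring. Among the compounds with values here, no measured step concerns a methoxy group or a change at this place, and the one step available, a 1.4-fold lower number from compound 1 to compound 2 (0.16 log units; within the scatter), shows that swapping a substituent on this ring had no effect beyond the scatter. Within the data shown here, nothing among the measured compounds points toward a shift in either direction, so the step from compound 2 is expected to be a 1.2-fold higher number from compound 2 to compound 3 (0.07 log units; within the scatter), within the scatter. Compound 3 is estimated at 36000 nM in this assay, most likely between 15000 nM and 85000 nM.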

Compound 3, half-maximal inhibitory concentration: 27600 nM
The estimate for compound 3 lay 1.3-fold (0.12 log units) above the measured number; the measured number falls inside the stated range.
By their numbers in this assay, from the lowest: compounds 3, 2 and 1 (each within the scatter of the next).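

In this assay, replacing 4-chlorophenyl with 3-methoxyphenyl on this nitrogen gives a 1.1-fold lower number from compound 2 to compound 3 (0.05 log units; within the scatter) and so does not separate the two substituted rings, even though the group and its place on the ring both differ. Going from the unsubstituted phenyl ring to 3-methoxyphenyl gives a 1.6-fold lower number from compound 1 to compound 3 (0.21 log units; within the scatter), which makes methoxy the second substituent on this ring, after chloro, to stay within the scatter of the unsubstituted phenyl ring. The data offer no independent measurement that could explain how close these numbers lie.

Going by these compounds alone, the chloro and methoxy groups each appear at only one place on the ring, so it remains open what either would do at the other place, and whether an amine or a carboxylic acid on this ring would move the number beyond the scatter. The benzyl group, the ethyl ester and the nitro group are the same in all three compounds, so these results say nothing about how changing any of them would affect the number.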